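The source may hold more compounds than are shown below. What is called first, only, known or untested is meant among the compounds shown, and "the series" means these compounds.

Measured in a physicochemical assay for solubility (on this read-out lower numbers stand for lower solubility and higher numbers for higher solubility), each entry a limit of the assay and not a number:

- compound 1 `CNC(=O)c1cc(C(=O)N[C@H]2[C@@H]3COC[C@@H]32)cc2c1OC[C@H]2c1cccc2[nH]ccc12`: >= 171 ug/mL
- compound 2 `CNC(=O)c1cc(C(=O)NC2CC2)cc2c1OC[C@H]2c1cccc(OC)c1`: >= 161 ug/mL
- compound 3 `CNC(=O)c1cc(C(=O)N[C@H]2[C@@H]3C[C@H](O)C[C@@H]32)cc2c1OC[C@@]2(C)c1ccccc1`: >= 151 ug/mL

Compound 3 gives >= 151 ug/mL, which is a limit. Among the measured compounds shown here, with all three entries limits, the compounds cannot be ranked, and no measured pair differs in one place only.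

Compound 4 `CNC(=O)c1cc(C(=O)N[C@H]2C[C@@H]2C)cc2c1OC[C@@]2(C)c1ccccc1` differs from compound 3 at one place: a group of 4 heavy atoms (4 carbon; one three-membered non-aromatic ring of carbon only) in place of a group of 7 heavy atoms (6 carbon, 1 oxygen; one three-membered non-aromatic ring of carbon only, one five-membered non-aromatic ring of carbon only), on an amide-type nitrogen. The group that enters is 2-methylcyclopropyl.

Compound 2, which also has a three-membered non-aromatic ring of carbon only on an amide-type nitrogen, reads >= 161 ug/mL, again a limit. On that basis, no step beyond the usual scatter is expected in this assay, though a small downward move remains possible. The expected change is an at least 1.1-fold lower number from compound 3 to compound 4 (0.06 log units; that floor lies within the scatter). Compound 4 is estimated at 130 ug/mL. The expected range for compound 4 runs from 50 ug/mL to 200 ug/mL, and a further limit would not be surprising.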

Compound 4, solubility: 3 ug/mL
Compound 4: the middle estimate sits 43-fold (1.64 log units) above what was measured, outside the stated range (below it).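

On this core, the group on the amide-type nitrogen is a sensitive place in this assay: exchanging the leaving group for 2-methylcyclopropyl gives an at least 50-fold lower number from compound 3 to compound 4 (1.70 log units; beyond the scatter). Among the compounds shown here, compound 4, at 3 ug/mL, provides the first actual number in the set, and it shows that this series can read far lower than the earlier entries indicated. Compound 3 stands at a limit, so the step gives only a minimum size: the limit of >= 151 ug/mL in this assay, at which 1 of the 4 values shown sits.

Which part of the exchange carries the step remains open, since the oxygen, the hydrogen-bond donor and acceptor, and the five-membered ring all go in one change. A 2-aminocyclopropyl group or a carboxylic acid-bearing cyclopropyl group on the same nitrogen would show whether the low value belongs to the three-membered ring itself.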